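The compounds below may be only part of what the source reports. "The series", "measured", "known", "first", "only" and "open" are said of these compounds alone.

The series keeps the core of compound 1 `CCNCCNC(=O)c1cc(Cl)c(N)cc1OC` and varies what sits on an amine nitrogen. In a functional assay on the whole organism with Rattus norvegicus as the target (on this read-out higher numbers stand for an effect only at larger amounts of compound and lower numbers for an effect already at smaller amounts), compound 1 gives > 30 mg/kg, which is a limit of the assay and not a number (the limit of > 30 mg/kg in this assay, at which 1 of the 2 values shown sits). Compound 2 `CCN(CCNC(=O)c1cc(Cl)c(N)cc1OC)Cc1ccccc1Cl` carries a 2-chlorobenzyl on that nitrogen; in this assay compound 2 gives 10 mg/kg. Among the measured compounds shown here, the step of an at least 3.0-fold lower number from compound 1 to compound 2 (0.47 log units; beyond the scatter) is the only measured step that bears on the change now considered. Compound 3 `CCN(CCNC(=O)c1cc(Cl)c(N)cc1OC)Cc1ccc(Cl)cc1Cl` is not yet measured; it differs from compound 1 by 2,4-dichlorobenzyl in place of hydrogen on an amine nitrogen. For the measured compounds named here, because compound 1 stands only at a limit (the limit of > 30 mg/kg in this assay, at which 1 of the 2 values shown sits), the size of the step from compound 1 to compound 3 can only be bounded from one side; a downward move in number at least as large as the one seen with compound 2 is expected. Near the value of compound 2, compound 3 is estimated at 10 mg/kg in this assay, with a range of 3 mg/kg to 30 mg/kg. This is expected to mean the step of an at least 3.0-fold lower number from compound 1 to compound 3 (0.47 log units; beyond the scatter).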

Compound 3, dose for half-maximal effect: 10 mg/kg
For compound 3 middle estimate and measured number coincide at the digits printed; the range from low to high includes it.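

Chloro in place of hydrogen on an aromatic carbon gives no change at the digits printed from compound 2 to compound 3 (within the scatter) in this assay, so at this amine nitrogen the added chlorine on the 2-chlorobenzyl group shows no separable effect on the read-out. The 2,4-dichlorobenzyl group gives an at least 3.0-fold lower number from compound 1 to compound 3 (0.47 log units; beyond the scatter), so a second substituted benzyl group now shares the move seen with compound 2. Compound 1 stands at a limit of the assay and not a number, so the steps from it are bounded from one side only: the limit of > 30 mg/kg in this assay, at which 1 of the 3 values shown sits.

The compounds shown leave open whether a plain benzyl group, or a 4-chlorobenzyl group without the other chlorine, sits with compound 2 and compound 3. Also open, from the compounds shown here alone, is whether a methyl group or a longer alkyl chain on that nitrogen, with no aromatic ring, gives a value clear of the limit.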